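This account rests on a few compounds, and the source may have more. Where it says the series, first, only, none or still open, it means among the compounds named here.

Measured compounds:
compound 1 `O=C(NC(=S)Nc1ccccc1)c1ccccc1F` — in an assay on isolated protein for inhibition of histone deacetylase 11 (Homo sapiens), read by fluorescence, tested at 100 uM (on this read-out higher numbers stand for more inhibition at the one concentration tested (going by the name of the read-out) and lower numbers for less inhibition), compound 1 is reported as "not active" (no number reported).
compound 2 `COc1cc(NC(=S)NC(=O)c2ccccc2)cc(OC)c1` — in this assay compound 2 gives 10%.

Two thioureas built on the same core have been tested so far. Compound 1 carries a fluoro group on one of its aromatic rings; in this assay it was simply called "not active" (no number reported), and no number accompanies that call, so compound 1 cannot be placed on a scale against compound 2. For the measured compounds named here, compound 2 differs in more than one place and gives a small read-out, 10%, which on its own says only that the shared core does little in this assay at the single concentration used.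

Compound 3 `O=C(NC(=S)Nc1ccccc1)c1ccccc1` is the untested partner of compound 1. The change from compound 1 to compound 3 is hydrogen in place of fluoro on an aromatic carbon. Going by the values given here, no measured pair shows this kind of step, so its size in this assay is unknown; the account expects no movement beyond the scatter, with a low read-out or another report of no activity. Compound 3 is therefore expected to give about 5%, somewhere between 0% and 20%.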

Compound 3, a percentage reported as inhibition, at one concentration (the size of the read-out at that concentration, not a potency): 14%
Compound 3: middle estimate off by 9 percentage points, on the low side, within the range that was stated.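

In this assay, for the compounds shown here, compound 1 is reported as "not active" (no number reported), so no step between it and compound 3 can be read, even though compound 3 gives 14%. The compounds shown leave open whether hydrogen in place of fluoro moves this read-out at all. Nothing available bears on the result of compound 3.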